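From Carbamoyl to Methoxy: Expected Stability of Compound 4

This account rests on a few compounds, and the source may have more. Where it says the series, first, only, none or still open, it means among the compounds named here.

Three compounds measured so far in an ADME assay on microsomes from liver (Mus musculus), read by LC-MS, using NADPH, with a stated time of 30 min, tested at 1 uM; a higher number here means that more of the compound is left, a lower number that less of the compound is left:
Compound 1 `C[C@H](Nc1nc(N)nc(N)c1C#N)c1c(-c2ccccc2)c(=O)n2cc(F)ccc2c1C1CC1`: 87%
Compound 2 `C[C@H](Nc1nc(N)nc(N)c1C#N)c1c(-c2ccccc2)c(=O)n2cc(F)ccc2c1-c1ccccc1`: 13%
Compound 3 `C[C@H](Nc1nc(N)nc(N)c1C#N)c1c(-c2ccccc2)c(=O)n2cc(F)ccc2c1-c1ccc(C(N)=O)cc1`: 97%

Compound 3 stands highest of the three in this assay, though its gap to compound 1 lies within the scatter, while compound 2 sits far below both. The step to compound 4 `COc1ccc(-c2c([C@H](C)Nc3nc(N)nc(N)c3C#N)c(-c3ccccc3)c(=O)n3cc(F)ccc23)cc1` is methoxy in place of carbamoyl on an aromatic carbon. Among the compounds with values here, two measured steps bear on it. The step of a number 84 percentage points higher from compound 2 to compound 3 (beyond the scatter) shows that taking the carbamoyl away entirely comes with a large loss, and the step of a number 10 percentage points higher from compound 1 to compound 3 (within the scatter) shows that the 4-carbamoylphenyl and the cyclopropyl give numbers within the scatter of each other. Within the data shown here, no measured compound carries a methoxy, so the size of this step cannot be read directly. Because the step of a number 84 percentage points higher from compound 2 to compound 3 (beyond the scatter) is large, a step downward is expected for compound 4, though a return all the way to the number of compound 2 is not assumed. For compound 4 the expected step is a number 52 percentage points lower from compound 3 to compound 4 (beyond the scatter). Compound 4 is therefore estimated at 45%, with a range from 10% to 85%.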

Compound 4, percent of the compound remaining: 82%
Estimate against measurement, compound 4: 37 percentage points below, and the stated range covers the measured number.
By their numbers in this assay, from the lowest: compound 2; then compounds 4, 1 and 3 (each within the scatter of the next, the first and the last beyond it).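

In this assay, within the data shown here, the carbamoyl turns out not to be the only group on this carbon that goes with a high number: methoxy in place of hydrogen gives a number 69 percentage points higher from compound 2 to compound 4 (beyond the scatter), a large step. Exchanging carbamoyl for methoxy gives only a number 15 percentage points lower from compound 3 to compound 4 (beyond the scatter), a modest step, even though the methoxy has no hydrogen-bond donor and the carbamoyl has one. The 4-methoxyphenyl and the cyclopropyl also stay close, with a number 5 percentage points lower from compound 1 to compound 4 (within the scatter), so among these four compounds only the unsubstituted phenyl of compound 2 stands far below the rest.

Nothing available explains why two such different groups give similar results here. From the compounds shown here alone, it remains open whether a methyl, a fluorine or a carboxylic acid on the same carbon would also go with a high number.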